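The source may hold more compounds than are shown below. What is called first, only, known or untested is meant among the compounds shown, and "the series" means these compounds.

Compound 1 `C[C@@H]1CCCN1c1c(C#N)c2c(N)nc(Nc3cn[nH]c3)nc2n1C`: 6 nM in an assay on isolated protein for inhibition of Leucine-rich repeat serine/threonine-protein kinase 2 (Homo sapiens), read by TR-FRET and LanthaScreen, with stated times of 50 min and 30 min, in the presence of a further agent that is not named here; a higher number here means a weaker inhibitor, a lower number a stronger inhibitor
Compound 2 `Cc1cn(C)nc1Nc1cc2c(c(N)n1)c(C#N)c(N1CCC[C@H]1C)n2C`: 2110 nM in this assay

Of the two numbers, compound 1 holds the lower one; the number for compound 2 stands far higher, well beyond the usual scatter. Compound 3 `C[C@@H]1CCCN1c1c(C#N)c2c(N)nc(Nc3cn(C)nc3C(F)(F)F)nc2n1C` differs from compound 1 in one place: 1-methyl-3-(trifluoromethyl)-1H-pyrazol-4-yl in place of 1H-pyrazol-4-yl on a nitrogen on an aromatic ring. Among the measured compounds shown here, no measured pair shows this same change, so the counted difference is the only guide. A step towards a weaker inhibitor is expected, a 10-fold higher number from compound 1 to compound 3 (1.00 log units; beyond the scatter) in this assay, of moderate size rather than a small one within the scatter. Compound 3 is accordingly estimated at 60 nM, with a range from 10 nM to 500 nM.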

Compound 3, half-maximal inhibitory concentration: 508 nM
Compound 3: the middle estimate sits 8.5-fold (0.93 log units) below what was measured, and the stated range ends below it.
By their numbers in this assay, from the lowest: compound 1; then compound 3; then compound 2.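

On a nitrogen on an aromatic ring, 1-methyl-3-(trifluoromethyl)-1H-pyrazol-4-yl in place of 1H-pyrazol-4-yl gives an 85-fold higher number from compound 1 to compound 3 (1.93 log units; beyond the scatter) in this assay, so this position is sensitive to the group it carries. The change adds heavy atoms and removes the counted hydrogen-bond donor, and this single step cannot separate those differences. Nothing available explains the rise.

From the compounds shown here alone, the methyl and the trifluoromethyl enter together, so the share of each stays open. Also open, going by these compounds, is how a pyrazole carrying only a methyl, or one carrying an amine, would compare.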